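The compounds below may be only part of what the source reports. "The series", "measured", "known", "first", "only" and "open" are said of these compounds alone.

Working notes on the series. Of the compounds shown here, two have numbers so far. Compound 1 `CC(C(=O)NCc1ccc(C(F)(F)F)nc1NCC1CCN(C(=O)OC(C)(C)C)CC1)c1ccc(NS(C)(=O)=O)c(F)c1` and compound 2 `Cc1ccc(Nc2nc(C(F)(F)F)ccc2CNC(=O)C(C)c2ccc(NS(C)(=O)=O)c(F)c2)cc1C` share a core and differ at the amino-bearing aromatic carbon. In a functional assay on CHO-K1 cells for antagonist activity at transient receptor potential cation channel subfamily V member 1 (Homo sapiens), read by FLIPR (on this read-out lower numbers stand for stronger inhibition and higher numbers for weaker inhibition), compound 1 gives 19.3 nM. In this assay compound 2 gives 39.3 nM, the higher of the two numbers, and the two values show compound 1 with the lower one. Compound 3 `CCCCN(C)c1nc(C(F)(F)F)ccc1CNC(=O)C(C)c1ccc(NS(C)(=O)=O)c(F)c1` has not been measured. It differs from compound 2 in one place: butyl(methyl)amino in place of (3,4-dimethylphenyl)amino on an aromatic carbon. Going by the values given here, no pair of measured compounds shows this change, so no measured step can be quoted for it. Both measured compounds carry an amino group with a hydrogen on that aromatic carbon, and compound 3 does not. The change from compound 2 to compound 3 is expected to give a step of a 2.0-fold higher number from compound 2 to compound 3 (0.31 log units; beyond the scatter), towards a higher number. Compound 3 is estimated at 80 nM, within 20 nM to 320 nM.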

Compound 3, inhibition constant: 0.8 nM
The estimate for compound 3 lay 100-fold (2.00 log units) above the measured number; the measured number lies below the stated range.
By their numbers in this assay, from the lowest: compound 3; then compound 1; then compound 2.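

In this assay, a 49-fold lower number from compound 2 to compound 3 (1.69 log units; beyond the scatter) shows that this aromatic carbon, next to the ring nitrogen, does not need an aromatic ring on its amino group: butyl(methyl)amino, with no ring, is accepted in place of (3,4-dimethylphenyl)amino. Both earlier compounds carry a hydrogen on that amino nitrogen, so they could not show whether a low number depends on it; compound 3, with 0 hydrogen-bond donors in this group, gives 0.8 nM. No measurement is at hand that bears on the cause of this large step.

The step removes the aromatic ring and the amino hydrogen together, and the compounds shown leave open how much of it belongs to each change. Butylamino, which keeps the hydrogen on the same chain, and a shorter chain such as dimethylamino remain open at this position.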